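Cyano versus carbamoyl on the shared core

The compounds below may be only part of what the source reports. "The series", "measured", "known", "first", "only" and "open" are said of these compounds alone.

Compound 1 `C[C@@H]1CCCN1c1[nH]c2ncnc(N)c2c1C#N` carries a cyano group and a ring nitrogen bearing no methyl group; in an assay on isolated protein for binding affinity to Leucine-rich repeat serine/threonine-protein kinase 2 variant G2019S (Homo sapiens), read by TR-FRET and LanthaScreen, with a stated time of 2 h (a higher number here means a weaker inhibitor, a lower number a stronger inhibitor), compound 1 gives 14 nM. Within the data shown here, compound 2 `C[C@@H]1CCCN1c1c(C(N)=O)c2c(N)ncnc2n1C` carries a carbamoyl group and a methyl group on the ring nitrogen; in this assay compound 2 gives 154 nM, the highest of the two numbers so far, with the gap to compound 1 lying beyond the scatter. Compound 3 `C[C@@H]1CCCN1c1c(C#N)c2c(N)ncnc2n1C` has not been measured; it differs from compound 2 in one place: cyano in place of carbamoyl on an aromatic carbon. Among the measured compounds shown here, no measured pair differs in this single place. Compound 3 shares the cyano group with compound 1 and the methyl on the ring nitrogen with compound 2, so its value is expected to fall within the span of those two values. The expected step is a 3.9-fold lower number from compound 2 to compound 3 (0.59 log units; beyond the scatter), toward a lower number, likely beyond the scatter. Compound 3 is expected at 40 nM, with a range from 10 nM to 160 nM.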

Compound 3, inhibition constant: 0.7 nM
For compound 3 the middle estimate is 57-fold (1.76 log units) above the measured one, and the stated range ends above it.
By their numbers in this assay, from the lowest: compound 3; then compound 1; then compound 2.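

Cyano in place of carbamoyl on the aromatic carbon, with the methyl on the ring nitrogen kept, gives a 220-fold lower number from compound 2 to compound 3 (2.34 log units; beyond the scatter) in this assay and so provides the first reading of this change in which nothing else differs. Methyl in place of hydrogen on the aromatic nitrogen, with the cyano group kept, gives a 20-fold lower number from compound 1 to compound 3 (1.30 log units; beyond the scatter) and separates the ring nitrogen from the change on the aromatic carbon, which the first two compounds could not do. No measurement is available here that bears on the origin of either step.

On these data alone, it remains open whether the methyl step also holds with carbamoyl on the aromatic carbon. As far as these compounds go, how an ethyl group on the ring nitrogen, or a primary amine or a carboxylic acid on the aromatic carbon, would compare also remains open.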